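From 3-Methoxyphenyl to 2-Methoxyphenyl: One Unmeasured Step

The source may hold more compounds than are shown below. What is called first, only, known or untested is meant among the compounds shown, and "the series" means these compounds.

In a functional assay on ECa-109 cells (Homo sapiens) for cytotoxicity, read by MTT assay, with a stated time of 72 h (a higher number here means a weaker inhibitor, a lower number a stronger inhibitor), compound 1 (`O=C1C(=Cc2ccc(F)cc2)C(=O)N(c2ccc(Cl)cc2)N1c1ccc(Cl)cc1`) gives 35600 nM, and compound 2 (`COc1cccc(C=C2C(=O)N(c3ccc(Cl)cc3)N(c3ccc(Cl)cc3)C2=O)c1`) gives 29000 nM. Within the data shown here, compound 2 therefore stands level with compound 1, the only other measured compound, since the two values lie within the scatter of each other.

Compound 3 (`COc1ccccc1C=C1C(=O)N(c2ccc(Cl)cc2)N(c2ccc(Cl)cc2)C1=O`) has not yet been measured. It differs from compound 2 by one change, 2-methoxyphenyl in place of 3-methoxyphenyl on a double-bonded chain carbon bound to a double-bonded ring carbon.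

Among the measured compounds shown here, only one measured step bears on this change. It swapped 4-fluorophenyl for 3-methoxyphenyl at the same place, and a 1.2-fold lower number from compound 1 to compound 2 (0.09 log units; within the scatter) stayed within the scatter. For the measured compounds named here, no measured pair shows what 2-methoxyphenyl does here, so this single step is weak evidence, and the range must stay wide. On that basis, no shift beyond the scatter is expected in this assay. The estimated change is a 1.1-fold lower number from compound 2 to compound 3 (0.03 log units; within the scatter). Compound 3 is estimated at 27000 nM, with an expected range from 11000 nM to 62000 nM.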

Compound 3, half-maximal inhibitory concentration: 30400 nM
Compound 3: the middle estimate sits 1.1-fold (0.05 log units) below what was measured; the range from low to high includes it.
By their numbers in this assay, from the lowest: compounds 2, 3 and 1 (each within the scatter of the next).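

In this assay, moving the methoxy group from the 3-methoxyphenyl to the 2-methoxyphenyl arrangement, on a double-bonded chain carbon bound to a double-bonded ring carbon, gives a 1.0-fold higher number from compound 2 to compound 3 (0.02 log units; within the scatter) and leaves the two isomers level. The earlier compounds had shown only one methoxyphenyl at this place, so this is the first sign that the read-out here does not separate the two placements of the methoxy group. Measured against 4-fluorophenyl, the 2-methoxyphenyl group gives a 1.2-fold lower number from compound 1 to compound 3 (0.07 log units; within the scatter), so all three substituted phenyl groups shown at this place now stand within the scatter of one another, and no compound among them stands apart. Nothing available offers an explanation for this level result.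

On these data alone, what remains open is whether 4-methoxyphenyl would stand level with these three, and whether anything other than a singly substituted phenyl at this place, such as a phenyl bearing an amine or a carboxylic acid, or a longer chain, would move the number beyond the scatter. The compounds shown also leave open whether this level pattern would hold in any cell line other than the one tested here.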